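This account rests on a few compounds, and the source may have more. Where it says the series, first, only, none or still open, it means among the compounds named here.

Of the compounds shown here, three that share one core have been read out in a functional assay (plasma) with Oryctolagus cuniculus as the target; on this read-out lower numbers stand for stronger inhibition and higher numbers for weaker inhibition. Compound 1 (`CCCC(CC(=O)N1CCC(Cn2c(C)nc3cnccc32)CC1)c1ccccc1`) gives 11 nM, compound 2 (`Cc1nc2cnccc2n1CC1CCN(C(=O)CC(C)(C)c2ccccc2)CC1`) gives 6.7 nM, and compound 3 (`Cc1nc2cnccc2n1CC1CCN(C(=O)N[C@H](C)c2ccccc2)CC1`) gives 13 nM. Compound 3 lies within the usual scatter of both other compounds, so these numbers set no order among the three.

The unmeasured compound 4 (`Cc1nc2cnccc2n1CC1CCN(C(=O)CN(C)c2ccccc2)CC1`) has the same atoms as compound 3, joined differently: (methyl(phenyl)amino)methyl in place of (1-phenylethyl)amino on a carbonyl carbon. In words, (methyl(phenyl)amino)methyl stands in place of (1-phenylethyl)amino on a carbonyl carbon.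

Going by the values given here, no measured step makes this exchange, so the data offer no direct guide. The closest evidence is a 1.6-fold lower number from compound 1 to compound 2 (0.22 log units; within the scatter), where 1-methyl-1-phenylethyl replaces 1-phenylbutyl on a saturated chain carbon bound to a carbonyl carbon. Among the compounds with values here, that step stays within the scatter, and it is the only measured step available.

Compound 3 stands at 13 nM in this assay. On this limited basis, compound 4 is expected to show no step beyond the scatter from compound 3, and no firm direction can be expected. The expected change, a slight lean only, is a 1.4-fold higher number from compound 3 to compound 4 (0.14 log units; within the scatter). For compound 4 the estimated value is 18 nM, with an expected range from 6 nM to 55 nM.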

Compound 4, half-maximal inhibitory concentration: 23 nM
Beside the measured number, compound 4's estimate is 1.3-fold (0.11 log units) below it; measured number inside the range.
By their numbers in this assay, from the lowest: compounds 2, 1, 3 and 4 (each within the scatter of the next, the first and the last beyond it).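

In this assay, going by these compounds alone, replacing (1-phenylethyl)amino with (methyl(phenyl)amino)methyl on the carbonyl carbon gives a 1.8-fold higher number from compound 3 to compound 4 (0.25 log units; within the scatter), so this rearrangement of the same atoms, which removes the hydrogen-bond donor and the defined stereocentre of the leaving group, produces no step that can be told from the scatter. Within the data shown here, at the saturated chain carbon bound to a carbonyl carbon, however, methyl(phenyl)amino brings the first steps in this set that lie beyond the scatter, both modest: a 3.4-fold higher number from compound 2 to compound 4 (0.54 log units; beyond the scatter) where it replaces 1-methyl-1-phenylethyl, and a 2.1-fold higher number from compound 1 to compound 4 (0.32 log units; beyond the scatter) where it replaces 1-phenylbutyl. Nothing measured here speaks to the reason for these steps.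

The compounds shown leave open how much of the shift depends on the methyl group on the nitrogen, a question that phenylamino at the same carbon would address. They also leave open whether the nitrogen itself matters, which a phenoxy group in place of methyl(phenyl)amino would test.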